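Chloro for Fluoro on a Benzoxazole Sulfonamide Core

The source may report more compounds than this note shows. Statements on the series, on what has been measured and on what is new or still open speak of the compounds shown alone.

The three measured compounds share a core in which an aryl sulfonamide hangs from a fused bicyclic ring. In an assay on cells for inhibition of HSP60/HSP10 (Homo sapiens), with a stated time of 60 min (on this read-out higher numbers stand for weaker inhibition and lower numbers for stronger inhibition), compound 1 (`O=S(=O)(Nc1ccc(-c2nc3ccccc3o2)cc1)c1cccc(F)c1`) gives 71000 nM. Compound 2 (`CS(=O)(=O)Nc1ccc(-c2nc3cc(NS(=O)(=O)c4ccc(Cl)s4)ccc3o2)cc1`), which carries a second sulfonamide on the fused ring, gives 43000 nM in this assay. Compound 3 (`O=S(=O)(Nc1ccc(-c2nc3cc(NS(=O)(=O)c4cccs4)ccc3o2)cc1)c1cccs1`), with two thiophene sulfonamides, gives 40000 nM in this assay. Compound 1 carries the highest of the three numbers, but its gaps to compound 2 and to compound 3 both sit within the usual scatter of repeated measurements, so the three are indistinguishable on these data.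

Compound 4 (`O=S(=O)(Nc1ccc(-c2nc3ccccc3o2)cc1)c1cccc(Cl)c1`) differs from compound 1 in one place: chloro in place of fluoro on an aromatic carbon. Chloro replaces fluoro on an aromatic carbon of the six-membered carbon-only ring, meta to the large group, so that a 3-fluorophenyl becomes a 3-chlorophenyl. Among the measured compounds shown here, no measured pair in this set shows the same change, so there is no step to lean on. The expectation for this assay is a step from compound 1 to compound 4 of a 1.2-fold lower number from compound 1 to compound 4 (0.07 log units; within the scatter), that is, no movement beyond the scatter. Compound 4 is therefore estimated at 60000 nM in this assay, within a range from 25000 nM to 140000 nM.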

Compound 4, half-maximal inhibitory concentration: 54000 nM
Compound 4: middle estimate off by 1.1-fold (0.05 log units), on the high side, within the range that was stated.
By their numbers in this assay, from the lowest: compounds 3, 2, 4 and 1 (each within the scatter of the next).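

Among the compounds shown here, this pair is the first in the set that differs in only one place, so a single change can now be read on its own. In this assay, chloro in place of fluoro on an aromatic carbon, meta to a large group, gives a 1.3-fold lower number from compound 1 to compound 4 (0.12 log units; within the scatter), which means that this pair shows no measurable difference between the two halogens at this spot. Nothing measured here speaks to why the number stays put, and no separate data on these compounds help to explain it.

Both groups are single halogen atoms, so this pair leaves open whether something quite different at this spot, such as an amine, a carboxylic acid or a longer chain, would shift the number beyond the scatter. It also leaves open whether chloro in place of fluoro would give a similarly small step on a core that carries a second sulfonamide, as the cores of compound 2 and compound 3 do.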